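Cytotoxicity limits and the step to compound 4

The source may report more compounds than this note shows. Statements on the series, on what has been measured and on what is new or still open speak of the compounds shown alone.

Three measured compounds frame this step: compound 1 `CC(=O)CSc1nc(Cc2c(F)cccc2F)cc(=O)[nH]1`, compound 2 `O=C(CSc1nc(Cc2c(F)cccc2F)cc(=O)[nH]1)c1ccc(Cl)cc1` and compound 3 `Cc1c(Cc2c(F)cccc2F)nc(SCc2ccc([N+](=O)[O-])cc2)[nH]c1=O`. In an ADME assay on MT4 cells (Homo sapiens) for cytotoxicity, read by MTT assay (a higher number here means that more compound is tolerated, a lower number that less compound is tolerated), compound 1 gives > 81000 nM, which is a limit. Compound 2 gives > 61000 nM, also a limit. Compound 3 gives > 37000 nM, again only a limit, so it has no numeric position among the three. Compound 4 `Cc1c(Cc2c(F)cccc2F)nc(SCc2cccnc2)[nH]c1=O` differs from it as follows: pyridin-3-yl in place of 4-nitrophenyl on a saturated chain carbon bound to a sulfur. Among the compounds with values here, the only measured step is a step that the two limits leave unreadable from compound 1 to compound 2. It lies at a different place and has no readable size, so no step beyond the scatter is expected. The estimated change is a step that the limit leaves unreadable from compound 3 to compound 4. In this assay compound 4 is expected at 60000 nM, with an estimated range of 25000 nM to 150000 nM.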

Compound 4, half-maximal cytotoxic concentration: > 70000 nM
Compound 4 was reported as a limit (the forecaster's own chance of this, stated with the estimate: 75%); middle value at least 1.1-fold (0.06 log units) away from the limit.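

In this assay compound 3 gives > 37000 nM, a limit. Compound 4 gives > 70000 nM, also a limit, so this pair yields no readable step. The compounds shown leave open whether pyridin-3-yl in place of 4-nitrophenyl shifts the cytotoxic concentration at all.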